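Side-chain change from compound 1 to compound 3

The source may report more compounds than this note shows. Statements on the series, on what has been measured and on what is new or still open speak of the compounds shown alone.

In a functional assay on OVCAR-8 cells (Homo sapiens) for antiproliferative activity (a lower number here means a stronger inhibitor, a higher number a weaker inhibitor), compound 1 (`Cn1ncc(Cl)c1-c1cc(C(=O)N[C@@H]2CN[C@H](CCNS(C)(=O)=O)C[C@H]2c2ccc(F)c(F)c2)oc1Cl`) gives 1530 nM, and compound 2 (`C=CC[C@@H]1C[C@@H](c2ccc(Cl)c(Cl)c2)[C@H](NC(=O)c2cc(-c3c(Cl)cnn3C)c(Cl)o2)CN1`) gives 990 nM. For the measured compounds named here, these two numbers lie within the usual scatter of each other, so compound 1 stands together with the only other measured compound and is not separated from it. Going by the values given here, no step between measured compounds that differ in one place is available yet.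

Compound 3 (`CC(=O)OCC[C@@H]1C[C@@H](c2ccc(F)c(F)c2)[C@H](NC(=O)c2cc(-c3c(Cl)cnn3C)c(Cl)o2)CN1`) keeps the core of compound 1 and changes one group: acetoxy in place of methanesulfonamido on a saturated chain carbon, two bonds along the chain from a saturated ring carbon. This places acetoxy in place of methanesulfonamido on a saturated chain carbon, two bonds along the chain from a saturated ring carbon.

Among the compounds with values here, the series holds no measured precedent for this change, so the expectation is anchored on compound 1 at 1530 nM. No step beyond the scatter is expected in this assay, in either direction, and the range is kept wide for lack of a precedent. The expected step is small, a 1.2-fold lower number from compound 1 to compound 3 (0.07 log units; within the scatter). For compound 3 the estimated value is 1300 nM, with an expected range of 550 nM to 3000 nM.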

Compound 3, half-maximal inhibitory concentration: 4960 nM
The estimate for compound 3 lay 3.8-fold (0.58 log units) below the measured number, and the stated range ends below it.
By their numbers in this assay, from the lowest: compounds 2 and 1 (each within the scatter of the next); then compound 3.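

In this assay, for the compounds shown here, the exchange of 2-(methanesulfonamido)ethyl for 2-acetoxyethyl gives a 3.2-fold higher number from compound 1 to compound 3 (0.51 log units; beyond the scatter) and is the first step, so this position on the chain does respond to the group it carries. The exchange removes the hydrogen-bond donor of methanesulfonamido while the count of acceptors stays the same, but it also replaces sulfur and nitrogen with carbon and oxygen, so a single pair cannot single out the donor as the feature that matters. Nothing available bears on why the number rises.

The compounds shown leave open whether the step follows the loss of the donor or the presence of the ester: an acetamido group or a free hydroxyl group on the same saturated chain carbon would separate these two readings. Also open, going by these compounds, is how far the position tolerates other kinds of group, such as a primary amine, a carboxylic acid or a longer chain carrying methanesulfonamido.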